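Clearance notes: furan-3-yl in place of 3-nitrophenyl

The compounds below may be only part of what the source reports. "The series", "measured", "known", "first", "only" and "open" are said of these compounds alone.

Compound 3 `O=C1O[C@@H](Cn2ccnn2)CN1c1ccc(N2CCN(Cc3cccc([N+](=O)[O-])c3)CC2)c(F)c1` gives 11.3 mL/min/kg in an in vivo ADME assay on the whole organism (strain Sprague-Dawley) for pharmacokinetics, with Rattus norvegicus as the target, at a dose of 50 mg/kg by the oral route (on this read-out higher numbers stand for fast clearance and lower numbers for slow clearance), and stands at the low end of the three numbers; compound 2 `O=C1O[C@@H](Cn2ccnn2)CN1c1ccc(N2CCN(Cc3ccc([N+](=O)[O-])o3)CC2)c(F)c1` gives 16.8 mL/min/kg and lies within the scatter of it, while compound 1 `Nc1ccc(CN2CCN(c3ccc(N4C[C@H](Cn5ccnn5)OC4=O)cc3F)CC2)cc1` gives 49 mL/min/kg and lies beyond. Compound 4 `O=C1O[C@@H](Cn2ccnn2)CN1c1ccc(N2CCN(Cc3ccoc3)CC2)c(F)c1` differs from compound 3 by furan-3-yl in place of 3-nitrophenyl on a saturated chain carbon bound to an amine nitrogen in a ring. Going by the values given here, the steps that bear on this site are a 4.3-fold lower number from compound 1 to compound 3 (0.64 log units; beyond the scatter) and a 1.5-fold lower number from compound 2 to compound 3 (0.17 log units; within the scatter): both nitro-bearing compounds sit at the slow end, the 4-aminophenyl compound at the fast end. Furan-3-yl carries neither group, so a move back toward faster clearance is expected, smaller than the aminophenyl step; for compound 4 the expected step is a 1.8-fold higher number from compound 3 to compound 4 (0.25 log units; within the scatter). Compound 4 is estimated at 20 mL/min/kg, with a range of 9 mL/min/kg to 45 mL/min/kg.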

Compound 4, clearance: 8.86 mL/min/kg
Beside the measured number, compound 4's estimate is 2.3-fold (0.35 log units) above it; measured number outside the range, below it.
By their numbers in this assay, from the lowest: compounds 4, 3 and 2 (each within the scatter of the next); then compound 1.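

A nitro group is not needed for slow clearance at this position: the nitro-free furan-3-yl gives a 1.3-fold lower number from compound 3 to compound 4 (0.11 log units; within the scatter) and a 1.9-fold lower number from compound 2 to compound 4 (0.28 log units; within the scatter), so these three groups cannot be told apart. Only 4-aminophenyl stands apart, with a 5.5-fold lower number from compound 1 to compound 4 (0.74 log units; beyond the scatter), and going from 9 heavy atoms to 5 leaves clearance within the scatter. No measured evidence explains this pattern. Still open, going by these compounds, is whether the amine or the ring drives the fast end of the series: unsubstituted phenyl and 3-aminophenyl on the same saturated chain carbon would separate the two.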